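The source may report more compounds than this note shows. Statements on the series, on what has been measured and on what is new or still open speak of the compounds shown alone.

Working notes on the series. The shared core is seen in compound 1 `O=C(NO)c1ccc(N(Cc2ccc(C(F)(F)F)cc2)C(=O)CN(Cc2ccccc2C(F)(F)F)S(=O)(=O)c2ccc(F)cc2)cc1`. In an assay on Sf9 cells for inhibition of histone deacetylase 8 (Homo sapiens), read by mobility shift assay (on this read-out higher numbers stand for weaker inhibition and lower numbers for stronger inhibition), compound 1 gives > 1000 nM, which is a limit of the assay and not a number. Compound 2 `CC(C)(C)c1ccc(CN(C(=O)CN(Cc2ccccc2C(F)(F)F)S(=O)(=O)c2ccc(F)c(F)c2)c2ccc(C(=O)NO)cc2)cc1` gives > 1000 nM, again only a limit. Compound 3 `CC(C)(C)c1ccc(CN(C(=O)CN(Cc2ccccc2C(F)(F)F)S(=O)(=O)c2ccc(F)cc2F)c2ccc(C(=O)NO)cc2)cc1` gives > 1000 nM, also a limit, so compound 3 stands at the limit of > 1000 nM in this assay, at which 3 of the 3 values shown sit. Among the measured compounds shown here, the one step with both ends measured, a step that the two limits leave unreadable from compound 2 to compound 3, cannot be read. Compound 4 `CC(C)(C)c1ccc(CN(C(=O)CN(Cc2ccccc2C(F)(F)F)S(=O)(=O)c2ccc(F)cc2)c2ccc(C(=O)NO)cc2)cc1` differs from compound 3 by hydrogen in place of fluoro on an aromatic carbon. For the measured compounds named here, no measured step bears on this change; compound 1, which carries the same (4-fluorophenyl)sulfonyl group, sits at the limit as well. Compound 4 is therefore expected to stay at the limit, with a step that the limit leaves unreadable from compound 3 to compound 4 as the expected step. The estimate for compound 4 is 3000 nM, in a range from 800 nM to 20000 nM.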

Compound 4, half-maximal inhibitory concentration: > 1000 nM
Compound 4 gave a limit, no number; the forecaster's own chance of this, stated with the estimate: 85%; the middle value does not contradict the limit.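

Compound 4 gives only a limit, like compound 1, compound 2 and compound 3, so no step among these compounds can be read: the limit of > 1000 nM in this assay, at which 4 of the 4 values shown sit. The compounds shown leave open how large any of these changes is in this assay.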